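From a methylphenyl to a dihydroindolyl group

This account rests on a few compounds, and the source may have more. Where it says the series, first, only, none or still open, it means among the compounds named here.

Values measured in a physicochemical assay for solubility; a higher number here means a more soluble compound, a lower number a less soluble compound:
- Compound 1 `CNC(=O)c1cc(C(=O)NC2CC2)cn(Cc2ccc(OC)cc2)c1=O`: >= 143 ug/mL (a limit)
- Compound 2 `CNC(=O)c1cc(C(=O)NC2CC2)cn(Cc2cccc3[nH]ccc23)c1=O`: 78 ug/mL
- Compound 3 `CNC(=O)c1cc(C(=O)NC2CC2)cn(Cc2cccc(C)c2)c1=O`: >= 205 ug/mL (a limit)

Compound 3 gives >= 205 ug/mL in this assay, and this is a limit rather than a number. The data show an at least 2.6-fold higher number from compound 2 to compound 3 (0.41 log units; beyond the scatter). Against the other limit, they show a step that the two limits leave unreadable from compound 1 to compound 3.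

Compound 4 `CNC(=O)c1cc(C(=O)NC2CC2)cn(Cc2cccc3c2CCN3)c1=O` differs from compound 3 in one place: 2,3-dihydro-1H-indol-4-yl in place of 3-methylphenyl on a saturated chain carbon bound to an aromatic nitrogen. The nearest measured group is the 1H-indol-4-yl of compound 2, so two steps bear on the change. The first, an at least 2.6-fold higher number from compound 2 to compound 3 (0.41 log units; beyond the scatter), is read here in reverse, as a modest fall on leaving 3-methylphenyl for a group of that kind. The second, an at least 1.8-fold lower number from compound 1 to compound 2 (0.26 log units; that floor lies within the scatter), points the same way but is weaker evidence. A modest fall in this assay is therefore expected, with a result near that of compound 2. The expected change is an at least 2.0-fold lower number from compound 3 to compound 4 (0.31 log units; beyond the scatter). Compound 4 is estimated at 100 ug/mL, with an expected range from 45 ug/mL to 220 ug/mL.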

Compound 4, solubility: >= 184 ug/mL
Compound 4: only a limit was reported; the forecaster's own chance of this, stated with the estimate: 15%; middle value at least 1.8-fold (0.26 log units) from the limit.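

In this assay compound 4 gives >= 184 ug/mL, and this is a limit of the assay, not a number. Among the compounds shown here, replacing 1H-indol-4-yl with 2,3-dihydro-1H-indol-4-yl on a saturated chain carbon bound to an aromatic nitrogen gives an at least 2.3-fold higher number from compound 2 to compound 4 (0.37 log units; beyond the scatter), so at this position the result for the one group does not carry over to the other, though the two differ only in the five-membered ring. The steps to compound 4 from compound 1 and from compound 3 cannot be read, with a limit at both ends of each.

On these data alone, how compounds 1, 3 and 4 rank in this assay stays open, as none of the three has a number. Also open, as far as these compounds go, is how a phenyl group carrying an amine or a carboxylic acid would behave at this place.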